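This account rests on a few compounds, and the source may have more. Where it says the series, first, only, none or still open, it means among the compounds named here.

Compound 1 `O=C(CCCCCCc1ccc(O)cc1)N1CCCC1` is the reference point of this small set. In an assay on HEK293 cells for inhibition of N-acylethanolamine-hydrolyzing acid amidase (Rattus norvegicus), read by LC-MS, with a stated time of 30 min (a lower number here means a stronger inhibitor, a higher number a weaker inhibitor), compound 1 gives 5600 nM. Within the data shown here, compound 2 `COc1ccc(CCCCCCC(=O)N2CCCC2)cc1` carries methyl in place of hydrogen on an oxygen on an aromatic ring, and in this assay compound 2 gives 35400 nM; the step of a 6.3-fold higher number from compound 1 to compound 2 (0.80 log units; beyond the scatter) is the one measured change. Compound 3 `O=C(O)c1cccc(CCCCCCC(=O)N2CCCC2)c1` belongs to a different core, and how the core of compound 1 and the core of compound 3 differ is not broken down here. For compound 3 this assay reports only a limit, > 100000 nM, which is the limit of > 100000 nM in this assay, at which 1 of the 3 values shown sits. Compound 4 `COC(=O)c1cccc(CCCCCCC(=O)N2CCCC2)c1` has not yet been measured and differs from compound 3 by methyl in place of hydrogen on an oxygen next to a carbonyl group. Among the measured compounds shown here, this is the same kind of change as the one from compound 1 to compound 2, but the place is not the same: there the oxygen sits on an aromatic ring with an aromatic carbon as other neighbour, here the oxygen sits next to a carbonyl group with the carbonyl carbon as other neighbour. The expected step that the limit leaves unreadable from compound 3 to compound 4 is an estimate resting on compound 3 standing at the limit and on the weakening seen in a 6.3-fold higher number from compound 1 to compound 2 (0.80 log units; beyond the scatter). Compound 4 is therefore expected to give about 150000 nM in this assay, between 30000 nM and 600000 nM.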

Compound 4, half-maximal inhibitory concentration: > 100000 nM
Compound 4 ended at the assay's limit; the forecaster's own chance of this, stated with the estimate: 65%; the middle value lies beyond the limit too.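

In this assay compound 4 gives > 100000 nM, which is a limit and not a number. Compound 3 also stands at a limit, and no step between compound 3 and compound 4 can be read: the limit of > 100000 nM in this assay, at which 2 of the 4 values shown sit.

The compounds shown leave open whether methyl in place of hydrogen on an oxygen next to a carbonyl group changes inhibition at all.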